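The source may hold more compounds than are shown below. What is called first, only, known or untested is meant among the compounds shown, and "the series" means these compounds.

Working notes on the series in a functional assay on HepG2 cells (Homo sapiens) for antiproliferative activity, read by MTT assay, with a stated time of 72 h; on this read-out higher numbers stand for weaker inhibition and lower numbers for stronger inhibition: compound 1 `NC1=NC2(CCSCC2)N(OCCCOc2ccc(Br)cc2)C(N)=N1` gives 1400 nM, compound 2 `NC1=NC2(CCSCC2)N(OCCCOc2cccc(Cl)c2Cl)C(N)=N1` gives 50 nM, and compound 3 `NC1=NC2(CCSCC2)N(OCCCOc2cccc(Br)c2)C(N)=N1` gives 90 nM. Compound 3 therefore sits with compound 2, the gap being a 1.8-fold higher number from compound 2 to compound 3 (0.26 log units; within the scatter), and well under compound 1.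

Next is compound 4 `NC1=NC2(CCSCC2)N(OCCCOc2ccc(Cl)cc2)C(N)=N1`: 4-chlorophenyl in place of 3-bromophenyl on an oxygen on a saturated carbon. The step bearing most directly on this change is a 16-fold lower number from compound 1 to compound 3 (1.19 log units; beyond the scatter), and a 28-fold lower number from compound 1 to compound 2 (1.45 log units; beyond the scatter) is also large. Going by the values given here, no measured step isolates chlorine for bromine. Compound 4 carries 4-chlorophenyl, which is closest by name to the 4-bromophenyl of compound 1, so a large step to a higher number is expected in this assay. The estimated step is an 11-fold higher number from compound 3 to compound 4 (1.05 log units; beyond the scatter). For compound 4 the expected value is 1000 nM, within an estimated range of 350 nM to 2800 nM.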

Compound 4, half-maximal inhibitory concentration: 1100 nM
Beside the measured number, compound 4's estimate is 1.1-fold (0.04 log units) below it; the measured number falls inside the stated range.
By their numbers in this assay, from the lowest: compounds 2 and 3 (each within the scatter of the next); then compounds 4 and 1 (each within the scatter of the next).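

In this assay, chloro in place of bromo on an aromatic carbon makes no difference beyond the scatter (a 1.3-fold lower number from compound 1 to compound 4 (0.10 log units; within the scatter)), so the high number seen with 4-bromophenyl also holds with 4-chlorophenyl. The large steps to 4-chlorophenyl from the other two aryl groups (a 12-fold higher number from compound 3 to compound 4 (1.09 log units; beyond the scatter); a 22-fold higher number from compound 2 to compound 4 (1.34 log units; beyond the scatter)) show that, among these four compounds, the split follows the aryl group's substitution pattern, not which halogen it carries. No measurement at hand explains this split.

Going by these compounds, it remains open whether 3-chlorophenyl would match 3-bromophenyl, and how unsubstituted phenyl, a methoxy group or an amine on the ring would behave.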